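Benzothiazolyl benzohydrazides: compound 4 in maltase-glucoamylase inhibition

The source may report more compounds than this note shows. Statements on the series, on what has been measured and on what is new or still open speak of the compounds shown alone.

Measured so far, in an assay on isolated protein for inhibition of Maltase-glucoamylase (Homo sapiens), with a stated time of 15 min; on this read-out higher numbers stand for weaker inhibition and lower numbers for stronger inhibition:
- compound 1 `COc1ccc(O)c(/C=N/NC(=O)c2ccc(-c3nc4ccccc4s3)cc2)c1` gives 6500 nM
- compound 2 `O=C(N/N=C/c1ccc(O)cc1O)c1ccc(-c2nc3ccccc3s2)cc1` gives 5580 nM
- compound 3 `O=C(N/N=C/c1ccc(F)c(Br)c1)c1ccc(-c2nc3ccccc3s2)cc1` gives 28000 nM

Compound 3 stands at the highest number of the three, beyond the scatter from both compound 1 and compound 2. Compound 4 `COc1cccc(/C=N/NC(=O)c2ccc(-c3nc4ccccc4s3)cc2)c1` is not yet measured. The change to reach it: 3-methoxyphenyl in place of 3-bromo-4-fluorophenyl on a carbon with a double bond to nitrogen.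

Among the measured compounds shown here, the steps that bear on it are those leaving the 3-bromo-4-fluorophenyl group: a 5.0-fold higher number from compound 2 to compound 3 (0.70 log units; beyond the scatter) and a 4.3-fold higher number from compound 1 to compound 3 (0.63 log units; beyond the scatter). Both read in the same direction, so departing from this group has given lower numbers in this assay for the two aryl groups measured. The 3-methoxyphenyl group carries no hydroxyl, unlike the aryl groups of compound 1 and compound 2, so the full size of those steps is not assumed. The expectation for compound 4 is a modest step downward from compound 3, a 2.0-fold lower number from compound 3 to compound 4 (0.30 log units; within the scatter), likely beyond the scatter but short of the numbers of compound 1 and compound 2.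

Compound 4 is estimated at 14000 nM in this assay, with a range of 6000 nM to 35000 nM.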

Compound 4, half-maximal inhibitory concentration: 11100 nM
Estimate against measurement, compound 4: 1.3-fold (0.10 log units) above; measured number inside the range.
By their numbers in this assay, from the lowest: compounds 2, 1 and 4 (each within the scatter of the next); then compound 3.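

In this assay, the drop from the 3-bromo-4-fluorophenyl group does not depend on a hydroxyl on the incoming aryl group, since 3-methoxyphenyl, which carries none, gives a step beyond the scatter (a 2.5-fold lower number from compound 3 to compound 4 (0.40 log units; beyond the scatter)). Hydrogen in place of hydroxy on an aromatic carbon gives a step within the scatter (a 1.7-fold higher number from compound 1 to compound 4 (0.23 log units; within the scatter)), and 3-methoxyphenyl in place of 2,4-dihydroxyphenyl does the same (a 2.0-fold higher number from compound 2 to compound 4 (0.30 log units; within the scatter)), so the hydroxyl groups of compound 1 and compound 2 show no separable change at this position. No data here bear on why the aryl groups differ.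

Which of the bromine and the fluorine goes with the higher number of compound 3 remains open. So does the reading at this position for an aryl group carrying an amine or a carboxylic acid.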